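A few compounds are considered here, and "the series" means these few. Any claim that something is new, unique, unknown or untested is made for them only; others in the source may bear on it.

Measured so far, in a functional assay on DLD-1 cells (Homo sapiens) for inhibition, read by MTT assay, with a stated time of 72 h; a lower number here means a stronger inhibitor, a higher number a weaker inhibitor: compound 1 `COc1cc(Oc2cccc(Nc3ccccc3)c2)cc(OC)c1CNCc1ccccc1` gives 5220 nM; compound 2 `COc1cc(Oc2cccc(Nc3ccccc3)c2)cc(OC)c1CNCc1ccc(F)cc1` gives 2650 nM; compound 3 `CNCc1c(OC)cc(Oc2cccc(Nc3ccccc3)c2)cc1OC` gives 11900 nM.

Compound 3 stands highest of the three numbers, so it is the weakest inhibitor of the set; its nearest neighbour is compound 1 and its furthest is compound 2. The step to compound 4 `COc1cc(Oc2cccc(Nc3ccccc3)c2)cc(OC)c1CNCCNC(C)=O` is acetamidomethyl in place of hydrogen on a saturated chain carbon bound to an amine nitrogen. Going by the values given here, no measured step shows exactly this change. What bears on it are the two steps that trimmed the substituent on the same amine nitrogen down to hydrogen: a 2.3-fold higher number from compound 1 to compound 3 (0.36 log units; beyond the scatter) and a 4.5-fold higher number from compound 2 to compound 3 (0.65 log units; beyond the scatter). Both went upward, so a substituent on that carbon has so far meant a lower number, though the entering group here carries no ring and brings an amide instead. A modest downward step in this assay is therefore expected for compound 4, of the order of a 1.7-fold lower number from compound 3 to compound 4 (0.23 log units; within the scatter), with a broad range since the group is of a new kind. Compound 4 is estimated at 7000 nM, between 3000 nM and 16000 nM.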

Compound 4, half-maximal inhibitory concentration: 6010 nM
The estimate for compound 4 lay 1.2-fold (0.07 log units) above the measured number, within the range that was stated.
By their numbers in this assay, from the lowest: compounds 2, 1, 4 and 3 (each within the scatter of the next, the first and the last beyond it).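

In this assay, going by these compounds alone, the acetamidomethyl group, which carries no ring, is the first entering group of its kind on this saturated chain carbon bound to an amine nitrogen, and a 2.0-fold lower number from compound 3 to compound 4 (0.30 log units; within the scatter) leaves it not separable from hydrogen there. Set against phenyl, a 1.2-fold higher number from compound 1 to compound 4 (0.06 log units; within the scatter) shows that a ring at this place is not needed to match compound 1, whereas a 2.3-fold higher number from compound 2 to compound 4 (0.36 log units; beyond the scatter) is the one new step beyond the scatter, so only the 4-fluorophenyl group stands apart from this chain. Nothing measured here gives a reason for these steps.

The 2-acetamidoethyl group is the only amide-bearing chain shown on this nitrogen. Going by these compounds, whether a free amine or a carboxylic acid at its end, or a longer chain, would shift the number remains open.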